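A few compounds are considered here, and "the series" means these few. Any claim that something is new, unique, unknown or untested is made for them only; others in the source may bear on it.

Working notes on the series.

The shared core carries an amino substituent whose variation is followed here. Going by the values given here, compound 1 `CCOCC(COCC)Nc1nc(C)nc2c(-c3ccc(OC)cc3C)c(C)nn12` gives 19.3 nM in an assay on cell membranes for displacement of a labelled ligand from corticotropin-releasing factor receptor 1 (Rattus norvegicus) (on this read-out lower numbers stand for stronger inhibition and higher numbers for weaker inhibition), the highest of the three numbers so far. Its nearest neighbour is compound 3 `COCC(COC)Nc1nc(C)nc2c(-c3ccc(OC)cc3C)c(C)nn12`, which gives 9.7 nM in this assay; the step of a 2.0-fold lower number from compound 1 to compound 3 (0.30 log units; within the scatter) lies within the scatter. Furthest away is compound 2 `CCC(CC)Nc1nc(C)nc2c(-c3ccc(OC)cc3)c(C)nn12`, which gives 3.8 nM in this assay; it differs from compound 1 in two places, so the gap cannot be assigned to either change.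

Compound 4 `CCCN(CC1CC1)c1nc(C)nc2c(-c3ccc(OC)cc3C)c(C)nn12` is not yet measured in this assay. Relative to compound 1 it carries (cyclopropylmethyl)(propyl)amino in place of (2-ethoxy-1-(ethoxymethyl)ethyl)amino on an aromatic carbon. Among the compounds with values here, only one measured step bears on this position, the step from compound 1 to compound 3, and that step stayed within the scatter while keeping the donor and both ether oxygens. Within the data shown here, no measured step tests the loss of the donor or the removal of the ether oxygens, so the change in compound 4 is largely untested in this set. The values of compound 2 show that a branched alkylamino without ether oxygens can sit at the lower end of the range, which is taken as weak support for a lower number. For compound 4 the expected step is a 3.2-fold lower number from compound 1 to compound 4 (0.51 log units; beyond the scatter). Compound 4 is therefore estimated at 6 nM, in the range 2 nM to 20 nM.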

Compound 4, half-maximal inhibitory concentration: 1.96 nM
The estimate for compound 4 lay 3.1-fold (0.49 log units) above the measured number, and the stated range ends above it.
By their numbers in this assay, from the lowest: compounds 4 and 2 (each within the scatter of the next); then compounds 3 and 1 (each within the scatter of the next).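

In this assay, going by these compounds alone, the position tolerates the swap to (cyclopropylmethyl)(propyl)amino: the series shows a 9.8-fold lower number from compound 1 to compound 4 (0.99 log units; beyond the scatter) and also a 4.9-fold lower number from compound 3 to compound 4 (0.69 log units; beyond the scatter) and, unlike the one earlier step at this position, both lie beyond the scatter. On the shared core with the same aryl group, neither the hydrogen-bond donor on the nitrogen nor the ether oxygens of the two leaving groups are therefore needed for a low number, and the compound with neither of them gives the lower number in both steps. No evidence is available on what lies behind these steps.

Each step changes the donor, the ether oxygens and the three-membered ring together, so the compounds shown do not divide the gain among these features. A (2-methoxyethyl)(propyl)amino group would keep an ether oxygen without the donor, and a dipropylamino group would drop the cyclopropyl ring while keeping the other features of compound 4, so either would begin to separate these contributions.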